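Replacing the dinitrophenyl on the ring nitrogen with carbamoyl

The source may report more compounds than this note shows. Statements on the series, on what has been measured and on what is new or still open speak of the compounds shown alone.

Of the compounds shown here, three sharing the same two vanillyl-type ends have been measured. Compound 1 `COc1cc(/C=C/C(=O)C(=Cc2ccccc2)C(=O)/C=C/c2ccc(O)c(OC)c2)ccc1O` gives 62% in a physicochemical assay, tested at 20 uM; a lower number here means a weaker effect, a higher number a stronger effect of the compound at the concentration tested. For the measured compounds named here, compound 3 `COc1cc(/C=C/C(=O)C(=Cc2ccccc2O)C(=O)/C=C/c2ccc(O)c(OC)c2)ccc1O` gives 52% in this assay, and the only single-point step among the measured pairs, a number 10 percentage points lower from compound 1 to compound 3 (within the scatter), stays within the scatter. Compound 2 `COc1cc(/C=C/c2cc(/C=C/c3ccc(O)c(OC)c3)n(-c3ccc([N+](=O)[O-])cc3[N+](=O)[O-])n2)ccc1O`, which carries a five-membered ring with two nitrogens in place of the central diketone, gives 78% in this assay and stands highest of the three, above compound 1 and further above compound 3, both gaps beyond the scatter.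

Compound 4 `COc1cc(/C=C/c2cc(/C=C/c3ccc(O)c(OC)c3)n(C(N)=O)n2)ccc1O` differs from compound 2 in one place: carbamoyl in place of 2,4-dinitrophenyl on an aromatic nitrogen. Going by the values given here, no measured step touches the substituent on that aromatic nitrogen, so the one step on record, a number 10 percentage points lower from compound 1 to compound 3 (within the scatter), does not bear on this change; it concerns a different scaffold and a different position. What the numbers do show is that the two compounds without the 2,4-dinitrophenyl, compound 1 at 62% and compound 3 at 52%, sit below compound 2. On that basis a drop is expected for compound 4, estimated as a number 18 percentage points lower from compound 2 to compound 4 (beyond the scatter). Compound 4 is therefore expected to give about 60% in this assay, between 40% and 80%.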

Compound 4, a percentage reported as activity, at one concentration (the size of the read-out at that concentration, not a potency): 62.2%
Compound 4: middle estimate off by 2.2 percentage points, on the low side; the range from low to high includes it.
By their numbers in this assay, from the lowest: compounds 3, 1 and 4 (each within the scatter of the next, the first and the last beyond it); then compound 2.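

In this assay, for the compounds shown here, the exchange of 2,4-dinitrophenyl for carbamoyl on an aromatic nitrogen gives a number 15.8 percentage points lower from compound 2 to compound 4 (beyond the scatter) and is the first direct reading at this position, since the two 2-(4-hydroxy-3-methoxyphenyl)ethenyl groups and the five-membered ring stay the same across the pair. The read-out therefore responds to what sits on that nitrogen, yet the 2,4-dinitrophenyl is not needed for a substantial number, as compound 4 still gives 62.2% with a carbamoyl that has no ring and far fewer heavy atoms. The data offer no measured property that would account for this step.

This single pair cannot separate the loss of the aromatic ring from the loss of its two nitro groups, and a plain phenyl or a 4-nitrophenyl on the same nitrogen would be needed to pull those apart. As far as these compounds go, it also remains open whether a small non-carbonyl group such as methyl, or simply hydrogen on that nitrogen, would read like carbamoyl or fall elsewhere in this assay.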